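The compounds below may be only part of what the source reports. "The series", "measured", "known", "first", "only" and "open" are said of these compounds alone.

Results in a functional assay on SW480 cells (Homo sapiens) for antiproliferative activity, read by MTT assay, with a stated time of 48 h; a lower number here means a stronger inhibitor, a higher number a weaker inhibitor:
- compound 1 `CC(CCO)n1cnc2c(Cl)nc(F)nc21`: 16800 nM
- compound 2 `CCC(CCO)n1cnc2c(Cl)nc(F)nc21`: 19800 nM
- compound 3 `CCC(CCO)n1cnc2c(Cl)ncnc21`: > 50000 nM (a limit of the assay, not a number)

Compound 2 sits alongside compound 1 among the true numbers, and the two cannot be told apart. The step between them reads a 1.2-fold higher number from compound 1 to compound 2 (0.07 log units; within the scatter). Compound 3 is the only one that ended at a limit.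

The next compound, compound 4 `CCCCC(CCO)n1cnc2c(Cl)nc(F)nc21`, is built from compound 2 by one change: ethyl in place of hydrogen on a saturated chain carbon, three bonds along the chain from an aromatic nitrogen. Cut one bond further out, this turns an ethyl into a butyl, so the chain simply grows.

The closest guide is the step just mentioned, where a methyl was added to a saturated chain carbon, two bonds along the chain from an aromatic nitrogen, and the number in this assay stayed within the scatter. The other measured step, an at least 2.5-fold higher number from compound 2 to compound 3 (0.40 log units; beyond the scatter), is larger, but it concerns the fluoro on an aromatic carbon, which compound 4 keeps, so it offers little guidance here.

One small step on the chain is thin evidence, but it points to no change beyond the scatter. The expected step is a 1.2-fold lower number from compound 2 to compound 4 (0.09 log units; within the scatter). For compound 4 the estimated value is 16000 nM, with an expected range of 7000 nM to 38000 nM.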

Compound 4, half-maximal inhibitory concentration: 13200 nM
The estimate for compound 4 lay 1.2-fold (0.08 log units) above the measured number, and the stated range covers the measured number.
By their numbers in this assay, from the lowest: compounds 4, 1 and 2 (each within the scatter of the next). At a limit, above all of these: compound 3.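

In this assay, growing the chain on this saturated chain carbon, three bonds along the chain from an aromatic nitrogen, does not move the number beyond the scatter: a 1.5-fold lower number from compound 2 to compound 4 (0.18 log units; within the scatter). The comparison with the shorter chain of compound 1 reads the same way, a 1.3-fold lower number from compound 1 to compound 4 (0.10 log units; within the scatter), so compounds 1, 2 and 4 cannot be told apart in this assay, and the tolerance seen earlier for one small methyl step now extends to a chain turned from ethyl to butyl. None of the measurements shown offers an explanation for why the number holds steady across these chains.

The compounds shown leave open how far this tolerance reaches, for instance whether a longer chain such as hexyl, a phenyl ring or an amine at the same carbon would still stay within the scatter. For the compounds shown here, they also leave open whether the butyl chain would give the same reading with hydrogen in place of the fluoro on the aromatic carbon, the one change so far that moved the number beyond the scatter.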